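This account rests on a few compounds, and the source may have more. Where it says the series, first, only, none or still open, it means among the compounds named here.

Measured in a physicochemical assay for solubility, read by nephelometry, measured as kinetic solubility, with a stated time of 30 min, at pH 2.0; on this read-out higher numbers stand for higher solubility and lower numbers for lower solubility:
- compound 1 `O=C(O)COc1ccc([C@H]2CC[C@]3(CC2)OOC2(O3)C3CC4CC2CC(C3)C4=O)cc1`: 50 ug/mL
- compound 2 `O=C(O)c1cc([C@H]2CC[C@]3(CC2)OOC2(O3)C3CC4CC(C3)CC2C4)ccc1O`: > 100 ug/mL (a limit)
- compound 3 `CCOC(=O)COc1ccc([C@H]2CC[C@]3(CC2)OOC2(O3)C3CC4CC(C3)CC2C4)cc1`: < 0.78 ug/mL (a limit)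

Compound 3 stands at the low end of these three readings, and its < 0.78 ug/mL is a limit of the assay, not a number. The next compound, compound 4 `O=C(O)c1ccc([C@H]2CC[C@]3(CC2)OOC2(O3)C3CC4CC(C3)CC2C4)cc1`, changes one place on compound 3, on an aromatic carbon of the six-membered ring, para to a large group: carboxy in place of (ethoxycarbonyl)methoxy (carboxy in place of (ethoxycarbonyl)methoxy on an aromatic carbon).

Compound 1 also carries a carboxy group and gives 50 ug/mL, which points to an upward move for compound 4. Compound 2 carries one too, and its > 100 ug/mL is also a limit. Both differ from compound 4 elsewhere as well, so they offer only a rough guide. The estimated step of an at least 15-fold higher number from compound 3 to compound 4 (1.18 log units; beyond the scatter) is expected to be large and upward in this assay, well beyond the usual scatter. Compound 4 is estimated at 12 ug/mL, with an expected range of 3 ug/mL to 50 ug/mL.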

Compound 4, solubility: < 1.6 ug/mL
Compound 4 was reported as a limit (the forecaster's own chance of this, stated with the estimate: 10%); middle value at least 7.5-fold (0.87 log units) away from the limit.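

Compound 3 and compound 4 are both reported only as limits, not as numbers, so the step between them cannot be read. The compounds shown leave open whether carboxy in place of (ethoxycarbonyl)methoxy shifts the reading in this assay at all, and in which direction.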